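From compound 3 to a phenylsulfanyl analogue

The source may hold more compounds than are shown below. What is called first, only, known or untested is meant among the compounds shown, and "the series" means these compounds.

In a functional assay for inhibition, with Homo sapiens as the target (on this read-out lower numbers stand for tighter binding and higher numbers for weaker binding), compound 3 `CC(C)(Oc1ccc(F)cc1[N+](=O)[O-])C1OCC(C/C=C\CCC(=O)O)C(c2cccnc2)O1` gives 2.51 nM, the lowest number of the three measured compounds and clearly apart from the other two. Compound 1 `CC(C)(Oc1ccc(F)cc1)C1OCC(C/C=C\CCC(=O)O)C(c2cccnc2)O1` gives 120 nM and compound 2 `CSc1ccccc1OC(C)(C)C1OCC(C/C=C\CCC(=O)O)C(c2cccnc2)O1` gives 89.1 nM. These two lie within the scatter of each other, with a 1.3-fold lower number from compound 1 to compound 2 (0.13 log units; within the scatter).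

The next structure, compound 4 `CC(C)(Sc1ccccc1)C1OCC(C/C=C\CCC(=O)O)C(c2cccnc2)O1`, follows from compound 3 by one change: a group of 7 heavy atoms (6 carbon, 1 sulfur; one six-membered aromatic ring of carbon only) in place of a group of 11 heavy atoms (6 carbon, 1 nitrogen, 3 oxygen, 1 fluorine; one six-membered aromatic ring of carbon only), on a saturated chain carbon bound to two saturated chain carbons and a saturated ring carbon. Like compound 1 and compound 2, it has no nitro group.

For the measured compounds named here, two measured steps bear on this. Nitro in place of hydrogen gave a large step, a 48-fold lower number from compound 1 to compound 3 (1.68 log units; beyond the scatter), and the other step into compound 3 was similar, a 35-fold lower number from compound 2 to compound 3 (1.55 log units; beyond the scatter). Both are beyond the scatter. Going by the values given here, no measured compound carries phenylsulfanyl itself, so the expectation remains uncertain.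

A large step towards a higher number in this assay is therefore expected, and the estimated step is a 40-fold higher number from compound 3 to compound 4 (1.60 log units; beyond the scatter). For compound 4 the expected value is 100 nM, with an estimated range from 25 nM to 400 nM.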

Compound 4, dissociation constant: 200 nM
For compound 4 the middle estimate is 2.0-fold (0.30 log units) below the measured one; the range from low to high includes it.
By their numbers in this assay, from the lowest: compound 3; then compounds 2, 1 and 4 (each within the scatter of the next, the first and the last beyond it).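

Compound 4 shows that phenylsulfanyl on this saturated chain carbon, with no nitro group, does not keep the low number of compound 3 in this assay (an 80-fold higher number from compound 3 to compound 4 (1.90 log units; beyond the scatter)). Set against the two compounds without nitro, the change is modest for 2-(methylsulfanyl)phenoxy (a 2.2-fold higher number from compound 2 to compound 4 (0.35 log units; beyond the scatter)) and stays within the scatter for 4-fluorophenoxy (a 1.7-fold higher number from compound 1 to compound 4 (0.22 log units; within the scatter)), so among these four compounds only compound 3, the one carrying nitro, stands apart. Nothing available accounts for these steps.

The compounds shown leave open whether nitro on the ring of phenylsulfanyl would give a large step like the one seen on 4-fluorophenoxy. They also leave open whether an amine or a nitrile in place of nitro would give such a step.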